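Replacing 4-Methylphenyl with Butyl on a Thiocarbonyl Nitrogen

The source may hold more compounds than are shown below. What is called first, only, known or untested is meant among the compounds shown, and "the series" means these compounds.

Compound 1, `COc1cc2c(cc1OC)C(=O)C(CC1CCN(C(=S)Nc3ccc(C)cc3)CC1)C2`, was tested in a functional assay on the whole organism (strain Swiss albino) with Mus musculus as the target, with a stated time of 4 h (on this read-out higher numbers stand for an effect only at larger amounts of compound and lower numbers for an effect already at smaller amounts), where compound 1 gives 300 mg/kg. Its closest measured relative is compound 2, `COc1cc2c(cc1OC)C(=O)C(CC1CCN(C(=S)Nc3ccccc3Cl)CC1)C2`, which in this assay gives 300 mg/kg; the step of no change at the digits printed from compound 1 to compound 2 (within the scatter) shows that exchanging one aromatic group for another left the read-out unchanged. Compound 3, `CCCCNC(=S)N1CCC(CC2Cc3cc(OC)c(OC)cc3C2=O)CC1`, is not yet measured. It differs from compound 1 by butyl in place of 4-methylphenyl on an amide-type nitrogen. Within the data shown here, the single measured step touches the same amide-type nitrogen, but there one six-membered aromatic ring gave way to another, whereas here the ring leaves and a butyl chain enters, so that step is only an indirect guide. With no other evidence, the expected step is no change at the digits printed from compound 1 to compound 3 (within the scatter), that is, none beyond the scatter. Compound 3 is estimated at 300 mg/kg, with a range from 100 mg/kg to 900 mg/kg.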

Compound 3, minimum effective dose: 300 mg/kg
Compound 3: the middle estimate sits on the measured number at the digits printed; low and high end bracket the measured number.
By their numbers in this assay, from the lowest: compounds 1, 2 and 3 (each within the scatter of the next).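

In this assay, the step from an aromatic group to a chain can now be read twice: with butyl in place of 4-methylphenyl the result is no change at the digits printed from compound 1 to compound 3 (within the scatter) and with butyl in place of 2-chlorophenyl it is no change at the digits printed from compound 2 to compound 3 (within the scatter) for this open-chain replacement. The earlier pair only exchanged one six-membered aromatic ring for another, whereas these steps show that, across these three compounds, the read-out stays level whether or not a ring sits on this amide-type nitrogen. Nothing measured here offers an explanation for this level result.

On these data alone, because all three compounds give the same value, it remains open whether any group on this nitrogen can move the read-out at all. A longer chain such as octyl, or a butyl chain ending in an amine or a carboxylic acid, could help to test this.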